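The source may hold more compounds than are shown below. What is called first, only, known or untested is meant among the compounds shown, and "the series" means these compounds.

Measured so far in a functional assay on A-375 cells (Homo sapiens) for cytotoxicity, read by MTT assay; on this read-out higher numbers stand for weaker inhibition and lower numbers for stronger inhibition:
- compound 1 `O=S(=O)(NCCCNc1nccc(-c2c(-c3cccc(F)c3)nc3sccn23)n1)c1cccc(F)c1`: 13700 nM
- compound 2 `O=S(=O)(NCCCNc1nccc(-c2c(-c3cccc(F)c3)nc3sccn23)n1)c1ccc(Cl)cc1`: 5900 nM
- compound 3 `Cc1ccc(S(=O)(=O)NCCNc2nccc(-c3c(-c4cccc(F)c4)nc4sccn34)n2)cc1`: 15400 nM

Compound 1 stands second highest of the three numbers. Within the data shown here, its nearest neighbour is compound 3, a 1.1-fold higher number from compound 1 to compound 3 (0.05 log units; within the scatter), so the two are not distinguishable; the only step beyond the scatter is a 2.3-fold lower number from compound 1 to compound 2 (0.37 log units; beyond the scatter).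

Compound 4 `O=C(NCCNc1nccc(-c2c(-c3cccc(F)c3)nc3sccn23)n1)c1ccccc1` is not yet measured. It differs from compound 1 by benzamido in place of (((3-fluorophenyl)sulfonyl)amino)methyl on a saturated chain carbon, two bonds along the chain from a nitrogen on an aromatic ring.

The shortening of the chain together with a new aryl sulfonyl was tolerated, as a 1.1-fold higher number from compound 1 to compound 3 (0.05 log units; within the scatter) shows. Among the measured compounds shown here, no measured step replaces the sulfonamide by an amide, so the expected step is small: a 1.1-fold lower number from compound 1 to compound 4 (0.06 log units; within the scatter) is estimated as within the scatter. Compound 4 is expected to give 12000 nM, with a range of 4000 nM to 36000 nM.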

Compound 4, half-maximal inhibitory concentration: 5060 nM
Compound 4: the middle estimate sits 2.4-fold (0.38 log units) above what was measured, and the stated range covers the measured number.
By their numbers in this assay, from the lowest: compounds 4 and 2 (each within the scatter of the next); then compounds 1 and 3 (each within the scatter of the next).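

In this assay, benzoyl in place of (4-methylphenyl)sulfonyl on an amine nitrogen gives a 3.0-fold lower number from compound 3 to compound 4 (0.48 log units; beyond the scatter) as the first measured step from a sulfonyl to a carbonyl at this nitrogen, with the rest of the molecule unchanged. Benzamido in place of the longer sulfonamide side chain gives a 2.7-fold lower number from compound 1 to compound 4 (0.43 log units; beyond the scatter) but only a 1.2-fold lower number from compound 2 to compound 4 (0.07 log units; within the scatter) so the amide separates from the 3-fluorophenyl sulfonamide and not from the 4-chlorophenyl one. No evidence here accounts for these steps.

Open, on these data alone, is whether a substituted benzoyl such as 4-chlorobenzoyl goes further than benzoyl. Also open, as far as these compounds go, is how the benzamide behaves on a longer chain, or with acetyl in place of benzoyl.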